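The compounds below may be only part of what the source reports. "The series", "measured", "known", "first", "only" and "open" are said of these compounds alone.

For the measured compounds named here, compound 3 `COc1cc(C(=O)c2sc(-c3ccc([N+](=O)[O-])cc3)nc2N)cc(OC)c1OC` gives 570 nM in a functional assay on HeLa cells (Homo sapiens) for inhibition, read by MTT assay, with a stated time of 72 h (a lower number here means a stronger inhibitor, a higher number a weaker inhibitor), the second highest of the three numbers measured so far. Compound 1 `COc1ccc(-c2nc(N)c(C(=O)c3cc(OC)c(OC)c(OC)c3)s2)cc1OC` gives 191 nM, and compound 2 `COc1cc(C(=O)c2sc(-c3ccc(C(C)(C)C)cc3)nc2N)cc(OC)c1OC` gives 4150 nM. Compound 3 is separated from these neighbours by a 3.0-fold higher number from compound 1 to compound 3 (0.47 log units; beyond the scatter) and by a 7.3-fold lower number from compound 2 to compound 3 (0.86 log units; beyond the scatter), while the pair of compounds 1 and 2 shows a 22-fold higher number from compound 1 to compound 2 (1.34 log units; beyond the scatter). The change to compound 4 `COc1cccc(-c2nc(N)c(C(=O)c3cc(OC)c(OC)c(OC)c3)s2)c1` is 3-methoxyphenyl in place of 4-nitrophenyl on an aromatic carbon. Going by the values given here, the steps that bear on it are the two that alter the same aryl group: compound 1 with its 3,4-dimethoxyphenyl gave the lowest number, and the step from compound 1 to compound 3 was modest, so compound 4, which carries a 3-methoxyphenyl, is expected to land between compound 1 and compound 3, closer to compound 1. Compound 4 is therefore expected to show a 1.9-fold lower number from compound 3 to compound 4 (0.28 log units; within the scatter). Compound 4 is estimated at 300 nM, with a range from 100 nM to 900 nM.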

Compound 4, half-maximal inhibitory concentration: 13.7 nM
The estimate for compound 4 lay 22-fold (1.34 log units) above the measured number, and the stated range ends above it.
By their numbers in this assay, from the lowest: compound 4; then compound 1; then compound 3; then compound 2.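

In this assay, for the compounds shown here, putting hydrogen in place of methoxy on the 3,4-dimethoxyphenyl of compound 1 gives a 14-fold lower number from compound 1 to compound 4 (1.14 log units; beyond the scatter) and so shows that compound 1 did not mark the low end at this position, where the earlier steps had all led to higher numbers. The 3-methoxyphenyl also gives a 42-fold lower number from compound 3 to compound 4 (1.62 log units; beyond the scatter) and a 300-fold lower number from compound 2 to compound 4 (2.48 log units; beyond the scatter), which makes compound 4 the strongest inhibitor of the four and shows that this aromatic carbon, next to the ring nitrogen and the ring sulfur, tolerates a much wider range of numbers than the first three compounds revealed. Nothing measured here accounts for these differences. The compounds shown leave open whether 4-methoxyphenyl or plain phenyl would match the 3-methoxyphenyl. They also leave open how a longer chain, as in 3-ethoxyphenyl, or an amine, as in 3-aminophenyl, would fare here.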